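From Ethoxycarbonyl to Nitro: Expecting Compound 3

This account rests on a few compounds, and the source may have more. Where it says the series, first, only, none or still open, it means among the compounds named here.

Of the compounds shown here, two have been measured so far. Compound 1 `Cc1c(CO/N=C/c2c(-c3ccccc3)nn(-c3ccccc3)c2Oc2ccc(Cl)cc2)cccc1-c1ccccc1` gives -10.1% in a functional assay on A549 cells (Homo sapiens) for antiproliferative activity, tested at 1 uM; a higher number here means more inhibition at the concentration tested (going by the name of the read-out), a lower number less inhibition. Compound 2 `CCOC(=O)c1ccc(CO/N=C/c2c(C)nn(C)c2Oc2ccc(Cl)cc2)cc1` gives 48.2% in this assay, the higher of the two numbers, and its gap to compound 1 lies beyond the scatter. Compound 3 `Cc1nn(C)c(Oc2ccc(Cl)cc2)c1/C=N/OCc1ccc([N+](=O)[O-])cc1` has not yet been measured. It differs from compound 2 in one place: nitro in place of ethoxycarbonyl on an aromatic carbon. Within the data shown here, no step between two measured compounds isolates this change, so the expectation rests on compound 2 alone. Because compound 2 reached 48.2% in this assay, compound 3 is expected to remain in the same region, with a step of a number 6.2 percentage points lower from compound 2 to compound 3 (within the scatter) that is expected to fall within the scatter or only a little below it. The estimate for compound 3 in this assay is 42%, within a range from 15% to 65%.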

Compound 3, a percentage reported as inhibition, at one concentration (the size of the read-out at that concentration, not a potency): 39.6%
Compound 3: middle estimate off by 2.4 percentage points, on the high side; the range from low to high includes it.
By their numbers in this assay, from the lowest: compound 1; then compounds 3 and 2 (each within the scatter of the next).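

Nitro in place of ethoxycarbonyl, on an aromatic carbon para to a large group, gives in this assay a number 8.6 percentage points lower from compound 2 to compound 3 (within the scatter) and so leaves the two compounds indistinguishable in this read-out. Among these compounds, this is the first direct look at this position, which the earlier pair could not give, since compound 1 and compound 2 differ in more than one place. Within this single pair, the inhibition does not depend on ethoxycarbonyl itself: nitro, with 3 heavy atoms against 5, serves equally well there.

As far as these compounds go, whether an amine or a carboxylic acid on the same carbon would hold this level remains open, as does whether the same exchange would read alike on the core of compound 1. No measurement shown here explains why the two groups read alike.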